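Orexin 2 antagonists: ether-to-benzyl switch on the core

A few compounds are considered here, and "the series" means these few. Any claim that something is new, unique, unknown or untested is made for them only; others in the source may bear on it.

Measured so far:
compound 1 `CCc1nc(Cl)c2n1CCN([C@@H](C(=O)NC)c1ccccc1)[C@H]2COc1ccc(C(F)(F)F)cc1` — 9 nM
compound 2 `CCc1nc(Cl)c2n1CCN([C@@H](C(=O)NC)c1ccccc1)[C@H]2COc1cccc(C(F)(F)F)c1` — 4 nM

Compound 2 stands at the lowest of the two numbers in a functional assay on CHO cells for antagonist activity at Orexin receptor type 2 (Homo sapiens), read by FLIPR and calcium flux; a higher number here means a weaker inhibitor, a lower number a stronger inhibitor; compound 1 lies one step above it, a 2.3-fold lower number from compound 1 to compound 2 (0.35 log units; beyond the scatter). Compound 3 `CCc1nc(Cl)c2n1CCN([C@@H](C(=O)NC)c1ccccc1)[C@H]2CCc1ccc(C(F)(F)F)c(Cl)c1` takes the change (3-chloro-4-(trifluoromethyl)benzyl in place of 3-(trifluoromethyl)phenoxy on a saturated chain carbon bound to a saturated ring carbon). Among the compounds with values here, no measured step bears on the oxygen-to-carbon exchange or on the added chlorine; only the single step from compound 1 to compound 2 speaks, and it concerns the position of the trifluoromethyl group alone, where moving it back toward the arrangement of compound 1 cost a modest amount. The expectation for compound 3 is therefore a modest rise in the number, a 2.5-fold higher number from compound 2 to compound 3 (0.40 log units; beyond the scatter), with a wide band to cover the untested exchange. The estimate for compound 3 is 10 nM, within 3 nM to 40 nM.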

Compound 3, half-maximal inhibitory concentration: 18 nM
The estimate for compound 3 lay 1.8-fold (0.26 log units) below the measured number, within the range that was stated.
By their numbers in this assay, from the lowest: compound 2; then compounds 1 and 3 (each within the scatter of the next).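

The saturated chain carbon bound to a saturated ring carbon tolerates the loss of the ether oxygen, with 3-chloro-4-(trifluoromethyl)benzyl still active in this assay. Against 3-(trifluoromethyl)phenoxy the change costs activity (a 4.5-fold higher number from compound 2 to compound 3 (0.65 log units; beyond the scatter)), whereas against 4-(trifluoromethyl)phenoxy it gives a step that does not separate the two groups (a 2.0-fold higher number from compound 1 to compound 3 (0.30 log units; within the scatter)), so the hydrogen-bond acceptor of the phenoxy groups is not required for activity, though the best number here still belongs to a phenoxy compound. No measurement at hand explains either step.

Oxygen-to-carbon exchange and added chlorine arrive together in compound 3, so their separate shares stay unresolved; a 3-(trifluoromethyl)benzyl group would divide them. As far as these compounds go, whether an amine nitrogen in place of the ether oxygen is tolerated also remains open.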